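The source may report more compounds than this note shows. Statements on the series, on what has been measured and on what is new or still open speak of the compounds shown alone.

Measured so far in an ADME assay for permeability, using PAMPA; on this read-out lower numbers stand for lower permeability and higher numbers for higher permeability:

Compound 1, `NCC(O)CNC(=O)/C=N/O`: 0.81 10^-6 cm/s
Compound 2, `CCN(CC)CCNC(=O)/C=N/O`: 1.1 10^-6 cm/s
Compound 3, `NCCNC(=O)/C=N/O`: 1.4 10^-6 cm/s

Compound 1 has the smallest number of the three, but its gaps to compound 2 and to compound 3 both fall within the usual scatter, so no real separation among these three is established. Compound 4, `O=C(/C=N/O)NCC(O)CO`, has not yet been run in this assay. Relative to compound 1 the change is hydroxy in place of amino on a saturated chain carbon, two bonds along the chain from an oxygen on a saturated carbon. Every group that leaves or enters here carries one hydrogen-bond donor and one hydrogen-bond acceptor, and no net charge is involved, so a step of any size beyond the scatter is not expected in this assay in either direction. For compound 4 the expected step from compound 1 is a 1.2-fold higher number from compound 1 to compound 4 (0.09 log units; within the scatter). Compound 4 is therefore estimated at 1 10^-6 cm/s, within a range from 0.5 10^-6 cm/s to 2 10^-6 cm/s.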

Compound 4, apparent permeability: 0.61 10^-6 cm/s
Compound 4: middle estimate off by 1.6-fold (0.21 log units), on the high side; low and high end bracket the measured number.
By their numbers in this assay, from the lowest: compounds 4, 1, 2 and 3 (each within the scatter of the next, the first and the last beyond it).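

In this assay, among the compounds shown here, hydroxy in place of amino on a saturated chain carbon, two bonds along the chain from an oxygen on a saturated carbon, gives a 1.3-fold lower number from compound 1 to compound 4 (0.12 log units; within the scatter) as the first single-place step. At this position, then, exchanging these two groups produces no separation beyond the scatter. Nothing at hand bears on the reason for this result.

Going by these compounds, whether a carboxylic acid or a longer chain at this position would give a step beyond the scatter stays open. So does whether the same exchange gives a comparable step elsewhere on the chain.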